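The compounds below may be only part of what the source reports. "The series", "measured", "known", "first", "only" and "open" are said of these compounds alone.

Measured so far in a functional assay on B16-F10 cells (Mus musculus) for antiproliferative activity, read by MTT assay, with a stated time of 48 h; on this read-out lower numbers stand for stronger inhibition and higher numbers for weaker inhibition:

- compound 1 `Cc1ccc(-c2cc(NC(=O)/C=C/c3ccc(Cl)cc3)n[nH]2)cc1`: 1520 nM
- compound 2 `O=C(/C=C/c1ccc(Cl)cc1)Nc1cc(-c2ccccc2)[nH]n1`: 1270 nM

Only these two compounds have numbers, and compound 2, at 1270 nM, lies within the usual scatter of compound 1, so the pair cannot be ranked. Among the measured compounds shown here, the only measured step is a 1.2-fold lower number from compound 1 to compound 2 (0.08 log units; within the scatter), with hydrogen in place of methyl on an aromatic carbon.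

The next compound, compound 3 `O=C(/C=C/c1ccc([N+](=O)[O-])cc1)Nc1cc(-c2ccccc2)[nH]n1`, differs from compound 2 in another place: nitro in place of chloro on an aromatic carbon. Here the nitro group replaces the chloro group, para to a large group. For the measured compounds named here, no measured pair shows what happens when chloro is replaced, so the step from compound 1 offers only weak guidance. It shows that one change elsewhere on the molecule left the number within the scatter, and it says nothing firm about this swap. With no direct evidence for a direction, no shift beyond the scatter is expected in this assay, though the uncertainty is wide. The expected step is a 1.1-fold higher number from compound 2 to compound 3 (0.04 log units; within the scatter). Compound 3 is estimated at 1400 nM, with an expected range of 450 nM to 4300 nM.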

Compound 3, half-maximal inhibitory concentration: 720 nM
Compound 3: the middle estimate sits 1.9-fold (0.29 log units) above what was measured; the measured number falls inside the stated range.
By their numbers in this assay, from the lowest: compounds 3, 2 and 1 (each within the scatter of the next, the first and the last beyond it).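

In this assay, putting nitro in place of chloro gives a 1.8-fold lower number from compound 2 to compound 3 (0.25 log units; within the scatter), so compound 2 and compound 3 cannot be ranked. Among the compounds shown here, this is the first measured change on this aromatic carbon, para to a large group, and it shows that a group of 3 heavy atoms with 2 hydrogen-bond acceptors can replace chloro, with 1 heavy atom and no acceptors, without a shift beyond the usual scatter of repeated measurements. No further data explain why the two numbers stay so close, or show whether the small gap between them is real.

Going by these compounds, with only chloro and nitro compared here, it remains open whether an amine, a methoxy group or a carboxylic acid at this position would move the number beyond the scatter. On these data alone, it also remains open whether the same swap would give a similar step on the core of compound 1, which carries a methyl group on its other aromatic ring.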